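Bromo to Phenyl: Expected Tolerance in Human Cells

The source may report more compounds than this note shows. Statements on the series, on what has been measured and on what is new or still open speak of the compounds shown alone.

Of the compounds shown here, three of one series have been tested in an ADME assay on HEK-293T cells (Homo sapiens) for cytotoxicity, read by luminescence, with a stated time of 24 h; a higher number here means that more compound is tolerated, a lower number that less compound is tolerated. Compound 1 `COc1ccc(Cn2c(C(=O)N3CCC(C(=O)NC(C)c4ccccc4)CC3)cc3sccc32)cc1` carries an amide-linked side chain on the shared core. In this assay compound 1 reaches only the limit of the measurement, > 100000 nM. Compound 2 `COc1ccc(Cn2c(C(=O)N3CCN(Cc4ccccc4)CC3)cc3sc(CNC(C)c4ccccc4)cc32)cc1` differs from it in its side chains. In this assay compound 2 stops at the limit as well, > 100000 nM. Compound 3 `CCCNC(=O)C1CCN(C(=O)c2cc3sc(Br)cc3n2Cc2ccc(OC)cc2)CC1` carries a bromo group on the core. In this assay compound 3 gives only a limit, > 100000 nM. Going by the values given here, compound 3 thus stands where every measured compound stands, (the limit of > 100000 nM in this assay, at which 3 of the 3 values shown sit), and no compound is separated from another by a number. Among the compounds with values here, no pair of measured compounds differs in just one place, so nothing shows how a change at the bromo position moves the read-out.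

Compound 4 `CCCNC(=O)C1CCN(C(=O)c2cc3sc(-c4ccccc4)cc3n2Cc2ccc(OC)cc2)CC1` has not been measured. It differs from compound 3 by phenyl in place of bromo on an aromatic carbon, in words phenyl in place of bromo on an aromatic carbon. Given that all three measured values sit at the limit (the limit of > 100000 nM in this assay, at which 3 of the 3 values shown sit), the step expected is a number no higher from compound 3 to compound 4 (the limit leaves the size open), none beyond the scatter. Compound 4 is therefore expected in this assay to come out near 100000 nM, within a range from 30000 nM to 300000 nM, most likely again as a limit rather than a number.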

Compound 4, half-maximal cytotoxic concentration: > 100000 nM
Compound 4: only a limit was reported (the forecaster's own chance of this, stated with the estimate: 70%); the middle value lies on the limit itself.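

Compound 3 and compound 4 both give only a limit in this assay, so no step can be read for phenyl in place of bromo on an aromatic carbon: the limit of > 100000 nM in this assay, at which 4 of the 4 values shown sit.

The compounds shown leave open at what concentration any of them stops being tolerated, and whether this change at that place alters that concentration.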